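A Methol-to-Ethoxy Step with No Precedent Yet Measured

The source may report more compounds than this note shows. Statements on the series, on what has been measured and on what is new or still open speak of the compounds shown alone.

Within the data shown here, compound 2 `COc1ccc(Nc2cc(NC(=O)c3ccccc3)ncn2)cc1` stands at the lower of the two numbers so far in an assay for inhibition of Receptor tyrosine-protein kinase erbB-3 variant L858R (Homo sapiens), read by mobility shift assay, with a stated time of 10 min (a lower number here means a stronger inhibitor, a higher number a weaker inhibitor), where compound 2 gives 60 nM. Among the measured compounds shown here, its nearest neighbour, compound 1 `COc1cccc(Nc2cc(Nc3ccc(S(N)(=O)=O)cc3)ncn2)c1`, gives 1850 nM in this assay, a gap beyond the scatter; no single-point step between these two is counted, so nothing more is read from that pair. Compound 3 `CCOc1ccc(Nc2cc(NC(=O)c3ccccc3)ncn2)cc1` has not yet been measured. It differs from compound 2 by methyl in place of hydrogen on a saturated chain carbon bound to an oxygen on an aromatic ring. For the measured compounds named here, because no step between measured compounds exists, there is no direct precedent for this change. A methyl added on a saturated chain carbon bound to an oxygen on an aromatic ring is expected to move the number little, and the step of a 1.3-fold higher number from compound 2 to compound 3 (0.12 log units; within the scatter) is estimated to stay within the scatter, in no firm direction. Compound 3 is therefore expected to give about 80 nM, within a range from 25 nM to 250 nM.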

Compound 3, half-maximal inhibitory concentration: 1210 nM
Compound 3: middle estimate off by 15-fold (1.18 log units), on the low side, and the stated range ends below it.
By their numbers in this assay, from the lowest: compound 2; then compounds 3 and 1 (each within the scatter of the next).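

The change from methoxy to ethoxy gives a 20-fold higher number from compound 2 to compound 3 (1.30 log units; beyond the scatter) in this assay, so a single added methyl at this place, on a saturated chain carbon bound to an oxygen on an aromatic ring, moves the number well beyond the scatter. Among these compounds, this is the first step that isolates one position, and it shows that the position does not tolerate this change freely, which no earlier comparison could show. No measurement shown here bears on the reason for this loss.

As far as these compounds go, it remains open whether a hydroxyl group in place of the methoxy would hold the number of compound 2, and whether a longer chain such as propoxy would raise it further. From the compounds shown here alone, whether the same added methyl costs as much on any other core also remains open.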